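The source may hold more compounds than are shown below. What is called first, only, known or untested is meant among the compounds shown, and "the series" means these compounds.

Compound 1 `CN1CCN(CCNCc2cn(-c3ccc(F)cc3F)nc2-c2cccc(Cl)c2)CC1` is where this account begins. Within the data shown here, in an ADME assay on Huh-7 cells (Homo sapiens) for cytotoxicity (a lower number here means that less compound is tolerated, a higher number that more compound is tolerated), compound 1 gives 15000 nM, the only plain number among the two measured compounds. Compound 2 `CN1CCN(CCNCc2cc(-c3ccccc3)nn2-c2ccc(F)cc2)CC1` is the other measured compound. In this assay compound 2 gives > 20000 nM, which is a limit of the assay and not a number, matching (the limit of > 20000 nM in this assay, at which 1 of the 2 values shown sits). Compound 3 `CN1CCN(CCNCc2cn(-c3ccc(F)cc3F)nc2C(C)(C)C)CC1` has not yet been measured. It differs from compound 1 in one place: tert-butyl in place of 3-chlorophenyl on an aromatic carbon. Among the measured compounds shown here, no step between two measured compounds is available, so the expectation rests on compound 1 alone and on the nature of the change. The expected step is small, a 1.2-fold higher number from compound 1 to compound 3 (0.08 log units; within the scatter), with no direction beyond the usual scatter of this kind of measurement. Compound 3 is therefore estimated to give 18000 nM in this assay, within a range from 8000 nM to 40000 nM, and a limit rather than a number is a real possibility.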

Compound 3, half-maximal cytotoxic concentration: > 20000 nM
Compound 3 was reported as a limit (the forecaster's own chance of this, stated with the estimate: 40%); at least 1.1-fold (0.04 log units) between middle value and limit.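

Compound 3 shows that this aromatic carbon, next to the ring nitrogen, can carry tert-butyl in place of 3-chlorophenyl with no ring on the group and no drop in the number in this assay: the change gives an at least 1.3-fold higher number from compound 1 to compound 3 (0.12 log units; that floor lies within the scatter). Only this floor can be read, and it does not separate the change from the scatter, so no gain in tolerance is established. The reading for compound 3 is a limit and not a number, which leaves the full size of the step unknown: the limit of > 20000 nM in this assay, at which 2 of the 3 values shown sit.

On these data alone, what a small group such as methyl would give on this aromatic carbon remains open. So does the outcome with a cyclohexyl ring, an amine or a carboxylic acid there.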